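This account rests on a few compounds, and the source may have more. Where it says the series, first, only, none or still open, it means among the compounds named here.

Working notes on the series. Going by the values given here, in a functional assay (aorta) with Rattus norvegicus as the target (a lower number here means that less compound is needed, a higher number that more compound is needed for the effect), only two compounds have numbers so far. Compound 1 (`O=C1CCCCN1C1=CC(CF)(CF)Oc2ccc([N+](=O)[O-])cc21`) gives 17.4 nM, and compound 2 (`N#Cc1ccc2c(c1)C(c1cccc[n+]1[O-])=CC(CF)(CF)O2`) gives 16.6 nM. These two values lie within the scatter of each other, so compound 2 stands level with compound 1 and no ranking can be drawn. Among the compounds with values here, the two structures differ in more than one place, so no single-change step has been measured.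

The next compound is compound 3 (`O=[N+]([O-])c1ccc2c(c1)C(c1cccc[n+]1[O-])=CC(CF)(CF)O2`), which has nitro in place of cyano on an aromatic carbon of compound 2: nitro in place of cyano on an aromatic carbon. Within the data shown here, the only evidence on a nitro-bearing structure is indirect: compound 1 carries a nitro group and gives 17.4 nM, on a structure that differs from compound 3 elsewhere. No step beyond the scatter is therefore expected in this assay, and neither direction is favoured. The expected change is a 1.1-fold lower number from compound 2 to compound 3 (0.04 log units; within the scatter), which is an estimate and stays within the scatter. For compound 3 the estimated value is 15 nM, with an expected range of 6 nM to 40 nM.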

Compound 3, half-maximal effective concentration: 1.74 nM
Compound 3: middle estimate off by 8.6-fold (0.94 log units), on the high side; measured number below the stated range.
By their numbers in this assay, from the lowest: compound 3; then compounds 2 and 1 (each within the scatter of the next).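

This aromatic position, meta to a fused ring and para to a fused ring, is not indifferent in this assay: nitro in place of cyano gives a 9.5-fold lower number from compound 2 to compound 3 (0.98 log units; beyond the scatter), a single-change step that compound 1 and compound 2, level with each other and differing in more than one place, could not show. With nitro held constant, the group on the double-bonded ring carbon also matters: a six-membered aromatic ring with 1 hetero atom in place of a six-membered non-aromatic ring with 1 hetero atom gives a 10-fold lower number from compound 1 to compound 3 (1.00 log units; beyond the scatter). Nothing at hand bears on the origin of either step.

The compounds shown leave open how other groups on that aromatic carbon would read, such as a trifluoromethyl group, an amine or a carboxylic acid, and whether cyano in place of nitro on the core of compound 1 would give a step of similar size. They also leave open how a plain phenyl ring or an open-chain amide on the double-bonded ring carbon would compare with the two rings seen so far.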